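The source may report more compounds than this note shows. Statements on the series, on what has been measured and on what is new or still open speak of the compounds shown alone.

In an ADME assay on microsomes from liver (Mus musculus) for metabolic stability, read by LC-MS, using NADPH, tested at 4.6 uM (a higher number here means that the compound lasts longer, a lower number that the compound disappears faster), compound 1 `O=C(NCCCCc1ccccc1)n1cc(-c2ccc(F)cc2)oc1=O` gives 1 h while compound 2 `O=C(NCCCCc1ccccc1)n1cc(-c2ccccn2)oc1=O` stands lower of the two at 0.167 h and differs from it by one group. That only measured step (a 6.0-fold lower number from compound 1 to compound 2 (0.78 log units; beyond the scatter)) put pyridin-2-yl in place of 4-fluorophenyl on an aromatic carbon. Compound 3 `O=C(NCCCCc1ccccc1)n1cc(-c2cnccn2)oc1=O` now carries pyrazin-2-yl in place of pyridin-2-yl at that same carbon (pyrazin-2-yl in place of pyridin-2-yl on an aromatic carbon). Within the data shown here, the one measured step swapped a different pair of groups, so it guides only weakly, and no shift beyond the scatter is expected in this assay here. The expected step is small (a 1.2-fold higher number from compound 2 to compound 3 (0.08 log units; within the scatter)). Compound 3 is estimated at 0.2 h (expected range 0.08 h to 0.5 h).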

Compound 3, half-life: 1 h
Compound 3: the middle estimate sits 5.0-fold (0.70 log units) below what was measured; the measured number lies above the stated range.
By their numbers in this assay, from the lowest: compound 2; then compounds 1 and 3 (each within the scatter of the next).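

In this assay, one more ring nitrogen at this carbon is enough to move the half-life, with a 6.0-fold higher number from compound 2 to compound 3 (0.78 log units; beyond the scatter). Pyrazin-2-yl and 4-fluorophenyl are not told apart here, with no change at the digits printed from compound 1 to compound 3 (within the scatter), so among these three groups only pyridin-2-y stands apart, and a nitrogen-containing ring as such does not go with a short half-life. No measurement at hand gives a reason for this difference.

From the compounds shown here alone, whether the number of ring nitrogens or their placement decides the outcome stays open, and pyridin-3-yl or pyrimidin-2-yl at the same carbon would separate the two. Going by these compounds, how an amine or a carboxylic acid on this ring would fare is also open.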